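Swapping the amide-side chain on a thiazole anti-HBV scaffold

The compounds below may be only part of what the source reports. "The series", "measured", "known", "first", "only" and "open" are said of these compounds alone.

Measured so far:
- compound 1, `CCCCCC(=O)Nc1ncc(C(Oc2ccc3cc(Br)ccc3c2)c2ccc(Cl)cc2)s1`: > 50000 nM
- compound 2, `CC(=O)O[C@@H]1OC(C(=O)Nc2ncc(C(Oc3ccc4cc(Br)ccc4c3)c3ccc(Cl)cc3)s2)[C@@H](OC(C)=O)[C@@H](OC(C)=O)[C@H]1OC(C)=O`: "not toxic" (no number reported)

In an ADME assay on HepG2 2.2.15 cells (Homo sapiens) for cytotoxicity (a higher number here means that more compound is tolerated, a lower number that less compound is tolerated), compound 1 reaches only a limit of the assay, > 50000 nM, as the limit of > 50000 nM in this assay, at which 1 of the 2 values shown sits, notes. Compound 2 was described as "not toxic" (no number reported) without a number. Among the compounds with values here, no step between two measured compounds can be drawn here.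

Compound 3, `O=S(=O)(Nc1ncc(C(Oc2ccc3cc(Br)ccc3c2)c2ccc(Cl)cc2)s1)c1ccc(Cl)nc1`, differs from compound 1 in one place: (6-chloropyridin-3-yl)sulfonyl in place of pentylcarbonyl on a nitrogen on an aromatic ring. Within the data shown here, with no measured step to lean on, the change from compound 1 to compound 3 is expected to move cytotoxicity little, perhaps slightly toward less tolerated, about an at least 1.2-fold lower number from compound 1 to compound 3 (0.09 log units; that floor lies within the scatter). Compound 3 is therefore estimated at 40000 nM, ranging from 10000 nM to 100000 nM.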

Compound 3, half-maximal cytotoxic concentration: "not toxic" (no number reported)
No number was reported for compound 3; there is nothing to compare the estimate with.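

No step can be read between compound 1 and compound 3, because compound 3 has no reported number and compound 1 reaches only a limit: the limit of > 50000 nM in this assay, at which 1 of the 3 values shown sits. Going by these compounds, whether swapping pentylcarbonyl for (6-chloropyridin-3-yl)sulfonyl changes how much compound the cells tolerate stays open.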